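Fluoro to hydroxy on compound 3

This account rests on a few compounds, and the source may have more. Where it says the series, first, only, none or still open, it means among the compounds named here.

In a functional assay on BHK-21 cells (Mesocricetus auratus) for antiproliferative activity, read by sulforhodamine B assay, with a stated time of 48 h, tested at 10 uM (a higher number here means more inhibition of growth at the concentration tested, a lower number less inhibition of growth), compound 1 (`O=[N+]([O-])c1cccc(C2=Nn3c(nnc3-c3ccncc3)SC2)c1`) stands at 62.5% while compound 2 (`Fc1ccc(-c2nn3c(-c4ccncc4)nnc3s2)cc1Cl`) stands at 46.3% and compound 3 (`Fc1ccc(OCc2nn3c(-c4ccncc4)nnc3s2)cc1`) at 48.3% in the same read-out. Compound 3 thus lies within the scatter of compound 2 and beyond the scatter below compound 1. Compound 4 (`Oc1ccc(OCc2nn3c(-c4ccncc4)nnc3s2)cc1`) differs from compound 3 by hydroxy in place of fluoro on an aromatic carbon with hydroxy in place of fluoro on an aromatic carbon. Within the data shown here, no measured pair here differs in one place, so no measured step sizes this change. No shift beyond the scatter is expected in either direction, and the estimated a number 2.3 percentage points lower from compound 3 to compound 4 (within the scatter) stays small. Compound 4 is estimated at 46% with an expected range from 30% to 62% in this assay for now.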

Compound 4, percent growth inhibition at one concentration: 56.2%
Compound 4: middle estimate off by 10.2 percentage points, on the low side; measured number inside the range.
By their numbers in this assay, from the lowest: compounds 2, 3, 4 and 1 (each within the scatter of the next, the first and the last beyond it).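

Among these compounds, the first one-place step, 4-fluorophenyl to 4-hydroxyphenyl, reads in this assay as a number 7.9 percentage points higher from compound 3 to compound 4 (within the scatter). On this aromatic carbon, para to a large group, hydroxy thus takes the place of fluoro without a shift beyond the scatter, even with a hydrogen-bond donor entering. No available evidence bears on the cause of this step.

Going by these compounds, whether an amine or a carboxylic acid at this position would leave the scatter remains open. So does whether the same change would read alike on the core of compound 1.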